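A few compounds are considered here, and "the series" means these few. Any claim that something is new, unique, unknown or untested is made for them only; others in the source may bear on it.

Working notes on the series, read in a functional assay on HL-60 cells (Homo sapiens) for cytotoxicity, read by WST assay, with a stated time of 48 h; a higher number here means a weaker inhibitor, a lower number a stronger inhibitor. Compound 1 `COc1cc(C(c2ccc(O)c(OC)c2)[C@@H](CO)C(C)C)ccc1O` gives > 100000 nM, which is a limit of the assay and not a number. Within the data shown here, compound 2 `COc1cc(C(c2ccc(O)c(OC)c2)[C@H](C)[C@H](C)CF)ccc1O` gives 56000 nM, the only true number so far. Among the measured compounds shown here, the single measured step is an at least 1.7-fold lower number from compound 1 to compound 2 (0.25 log units; that floor lies within the scatter). That step starts from the limit of > 100000 nM in this assay, at which 1 of the 2 values shown sits, and replaces a whole group, so it gives no measure of a change in configuration alone. Compound 3 `COc1cc(C(c2ccc(O)c(OC)c2)[C@H](C)[C@@H](C)CF)ccc1O` has the same atoms and bonds as compound 2: the two compounds have the same atoms and bonds and differ only in configuration as drawn: 1 of 2 stereo elements differ; a stereocentre at a saturated chain carbon is drawn S in compound 2 and R in compound 3. A stereocentre at a saturated chain carbon is drawn S in compound 2 and R in compound 3. For the measured compounds named here, no measured pair isolates such a change, so no step beyond the scatter is expected in this assay and no direction is predicted. The expected result is a 1.1-fold higher number from compound 2 to compound 3 (0.03 log units; within the scatter), within the scatter. Compound 3 is estimated at 60000 nM, with an expected range from 28000 nM to 100000 nM.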

Compound 3, half-maximal inhibitory concentration: 45000 nM
Compound 3: the middle estimate sits 1.3-fold (0.12 log units) above what was measured; the range from low to high includes it.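

In this assay, a change of configuration alone now has a measured step (a 1.2-fold lower number from compound 2 to compound 3 (0.09 log units; within the scatter)), so the S and R forms drawn at this saturated chain carbon cannot be told apart, and the comparison is a direct one: the fact that compounds 2 and 3 differ only in the configuration as drawn. The replacement of 1-(hydroxymethyl)-2-methylpropyl by 2-(fluoromethyl)-1-methylpropyl now gives a floor beyond the scatter (an at least 2.2-fold lower number from compound 1 to compound 3 (0.34 log units; beyond the scatter)). Compound 1 stands at a limit and not at a number, so this step shows no true size: the limit of > 100000 nM in this assay, at which 1 of the 3 values shown sits.

As far as these compounds go, whether the other stereo element of the chain matters in this assay remains open. Also open, from the compounds shown here alone, is what a hydroxymethyl group, an amine or a carboxylic acid would give in place of the fluoromethyl group on the 1-methylpropyl chain.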